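Chloro for methoxy on the seven-membered ring: compound 4

The source may report more compounds than this note shows. Statements on the series, on what has been measured and on what is new or still open speak of the compounds shown alone.

Measured in a functional assay on the whole organism (strain Sprague-Dawley CD) for inhibition, with Rattus norvegicus as the target, read by paw edema, at a dose of 30 mg/kg by the intraperitoneal route; a higher number here means a stronger effect of the compound at the dose given, a lower number a weaker effect:
compound 1 `CCOC(=O)C(=O)Nc1cccccc1=O`: 84%
compound 2 `CCOC(=O)C(=O)Nc1ccccc(N(C)C(=O)C(=O)OCC)c1=O`: 51%
compound 3 `CCOC(=O)C(=O)Nc1ccc(OC)ccc1=O`: 8%

Compound 3 stands lowest of the three numbers; compound 2 is nearest and compound 1 furthest, both gaps beyond the scatter. Among the measured compounds shown here, the only single-change step recorded is a number 76 percentage points lower from compound 1 to compound 3 (beyond the scatter), and it is the only one that bears on the next compound. Compound 4 `CCOC(=O)C(=O)Nc1ccc(Cl)ccc1=O` carries chloro in place of methoxy on an aromatic carbon. For the measured compounds named here, no measured pair shows what chloro does at this carbon; the methoxy step shows only that a group here can cut the effect sharply. Compound 4 is expected to fall between the two measured extremes, and the expected step is a number 22 percentage points higher from compound 3 to compound 4 (beyond the scatter), uncertain in size. The estimate for compound 4 is 30%, within 5% to 65%.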

Compound 4, a percentage reported as inhibition, in the whole organism at one dose (the size of the read-out at that dose, not a potency): 27%
The estimate for compound 4 lay 3 percentage points above the measured number; low and high end bracket the measured number.
By their numbers in this assay, from the lowest: compound 3; then compound 4; then compound 2; then compound 1.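

In this assay, a second group can now be read on the aromatic carbon three ring bonds from the ring atom that bears a group of 8 heavy atoms: chloro in place of hydrogen gives a number 57 percentage points lower from compound 1 to compound 4 (beyond the scatter), so a large loss is not confined to methoxy. Chloro in place of methoxy recovers only part of that loss, with a number 19 percentage points higher from compound 3 to compound 4 (beyond the scatter). Nothing at hand explains the difference between these two groups.

On these data alone, whether an amine or a carboxylic acid on this carbon would retain the effect of compound 1 remains open.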